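Amine swap on compound 1: notes toward compound 4

This account rests on a few compounds, and the source may have more. Where it says the series, first, only, none or still open, it means among the compounds named here.

compound 1: `CN(C)Cc1ccc2nc(NC(=O)N/N=C3\C(=O)Nc4ccc(F)cc43)sc2c1`, 2310 nM
compound 2: `Cc1ccc(Cn2cc(/C=N/NC(=O)Nc3nc4ccc(CN(C)C)cc4s3)c3ccccc32)cc1`, 1600 nM
compound 3: `CC1CCN(Cc2ccc3nc(NC(=O)N/N=C/c4cn(Cc5ccccc5Cl)c5ccccc45)sc3c2)CC1`, 3330 nM

Three compounds have numbers in a functional assay on A549 cells (Homo sapiens) for cytotoxicity, read by MTT assay, with a stated time of 72 h; a lower number here means a stronger inhibitor, a higher number a weaker inhibitor. Compound 1 gives 2310 nM, the second highest of the three; compound 3 sits nearest at 3330 nM and compound 2 furthest at 1600 nM, both within the usual scatter of this assay. Compound 4 is `CC1CCN(Cc2ccc3nc(NC(=O)N/N=C4\C(=O)Nc5ccc(F)cc54)sc3c2)CC1`, differing from compound 1 by 4-methylpiperidin-1-yl in place of dimethylamino on a saturated chain carbon bound to an aromatic carbon. For the measured compounds named here, no measured pair isolates this change. Compound 3, carrying 4-methylpiperidin-1-yl on another core, and compound 2, carrying dimethylamino, give values within the scatter of each other, which offers no hint of a shift. A change no larger than the scatter is therefore expected, a 1.2-fold higher number from compound 1 to compound 4 (0.07 log units; within the scatter). Compound 4 is estimated at 2700 nM, between 1300 nM and 5600 nM.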

Compound 4, half-maximal inhibitory concentration: 3010 nM
Compound 4: the middle estimate sits 1.1-fold (0.05 log units) below what was measured, and the stated range covers the measured number.
By their numbers in this assay, from the lowest: compounds 2, 1, 4 and 3 (each within the scatter of the next, the first and the last beyond it).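

In this assay, for the compounds shown here, the one pair that isolates this swap gives a 1.3-fold higher number from compound 1 to compound 4 (0.11 log units; within the scatter) and does not separate (dimethylamino)methyl from (4-methylpiperidin-1-yl)methyl on the core of compound 1. This position therefore accepts the 7 heavy atoms and six-membered non-aromatic ring of 4-methylpiperidin-1-yl in place of the 3 heavy atoms of dimethylamino, with the two values within the scatter of each other. Nothing at hand gives a reason for this result.

Open, from the compounds shown here alone, is how a morpholine ring, a primary amine or a carboxylic acid would read on the same saturated chain carbon. Also open, going by these compounds, is whether the same swap reads alike on the core of compound 3.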